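A few compounds are considered here, and "the series" means these few. Any claim that something is new, unique, unknown or untested is made for them only; others in the source may bear on it.

The measured compounds:

Compound 1, `N#Cc1ccc(/C=N/NC(=O)Nc2ccc(Oc3ccnc4[nH]ccc34)c(F)c2)cc1`: in a functional assay on PC-3 cells (Homo sapiens) for antiproliferative activity, read by MTT assay, with a stated time of 72 h (on this read-out lower numbers stand for stronger inhibition and higher numbers for weaker inhibition), compound 1 gives 9030 nM.
Compound 2, `O=C(N/N=C/c1ccc(O)cc1)Nc1ccc(Oc2ccnc3[nH]ccc23)cc1`: in this assay compound 2 gives 4920 nM.
Compound 3, `COc1ccc(/C=N/NC(=O)Nc2ccc(Oc3ccnc4[nH]ccc34)cc2)cc1`: in this assay compound 3 is reported as "not active" (no number reported), without a number.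

All three share the same core and differ only in the group carried on the carbon with a double bond to nitrogen. Among the two numbers, compound 1 has the higher one, and compound 2 stands nearest, yet that gap lies within the usual scatter of repeated measurements, so no ordering between the two can be read from it. Compound 3 gives no number at all. Within the data shown here, no single step between measured compounds is available to guide an expectation.

Compound 4, `CN(C)CCn1cccc1/C=N/NC(=O)Nc1ccc(Oc2ccnc3[nH]ccc23)c(F)c1`, arises from compound 1 by the change (1-(2-(dimethylamino)ethyl)-1H-pyrrol-2-yl in place of 4-cyanophenyl on a carbon with a double bond to nitrogen). With so little to build on, the step from compound 1 to compound 4 is expected to be small, a 1.8-fold lower number from compound 1 to compound 4 (0.26 log units; within the scatter), at most a mild move towards a lower number and possibly none beyond the scatter. Compound 4 is therefore estimated at 5000 nM, with a plausible range from 1000 nM to 25000 nM.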

Compound 4, half-maximal inhibitory concentration: 1600 nM
Compound 4: the middle estimate sits 3.1-fold (0.49 log units) above what was measured; the range from low to high includes it.
By their numbers in this assay, from the lowest: compound 4; then compounds 2 and 1 (each within the scatter of the next).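

In this assay, among these compounds, the group on a carbon with a double bond to nitrogen turns out to be able to move the number: 1-(2-(dimethylamino)ethyl)-1H-pyrrol-2-yl in place of 4-cyanophenyl gives a 5.6-fold lower number from compound 1 to compound 4 (0.75 log units; beyond the scatter), the first step beyond the scatter at this position. The ring and the side chain change together in this swap, as a six-membered aromatic ring of carbon only gives way to a five-membered aromatic ring with 1 hetero atom that also bears the chain. Nothing measured here accounts for the step.

The compounds shown do not separate the five-membered ring from its chain. The same ring with no chain, with a longer chain, or with a carboxylic acid in place of the dimethylamino group would show which part goes with the step.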